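Solubility notes on the series: from compound 3 to compound 4

The compounds below may be only part of what the source reports. "The series", "measured", "known", "first", "only" and "open" are said of these compounds alone.

Of the compounds shown here, three have been measured in a physicochemical assay for solubility, measured as kinetic solubility, at pH 7.4; on this read-out higher numbers stand for higher solubility and lower numbers for lower solubility. Compound 1 `COc1cc(N2CCN(C(=O)C3CCC(O)CC3)CC2)ccc1Nc1nc(NC2CCCCC2)c2nc[nH]c2n1` gives 19000 nM. Compound 2 `COc1cc(N2CCN(Cc3ccccn3)CC2)ccc1Nc1nc(NC2CCCCC2)c2nc[nH]c2n1` gives 38000 nM. Compound 3 `COc1cc(N2CCN(CC3CCOC3)CC2)ccc1Nc1nc(NC2CCCCC2)c2nc[nH]c2n1` gives 5000 nM, the lowest of the three numbers. The steps among them are a 2.0-fold higher number from compound 1 to compound 2 (0.30 log units; within the scatter), a 3.8-fold lower number from compound 1 to compound 3 (0.58 log units; beyond the scatter) and a 7.6-fold lower number from compound 2 to compound 3 (0.88 log units; beyond the scatter), so compound 3 sits below both of the others, nearest to compound 1 and furthest from compound 2.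

Compound 4 `CCN(CC)CC1CCN(c2ccc(Nc3nc(NC4CCCCC4)c4nc[nH]c4n3)c(OC)c2)CC1` has not yet been measured in this assay. The change from compound 3 is 4-((diethylamino)methyl)piperidin-1-yl in place of 4-((oxolan-3-yl)methyl)piperazin-1-yl on an aromatic carbon. For the measured compounds named here, no measured step replaces this whole group, so the bearing of the earlier steps is indirect: the steps from compound 1 and from compound 2 to compound 3 show that the group carrying the oxolan-3-yl chain gave the lowest number of the three, and its removal is read as more likely to raise than to lower the number, by a modest amount. On that basis compound 4 is expected to show a 4.0-fold higher number from compound 3 to compound 4 (0.60 log units; beyond the scatter). The estimate for compound 4 is 20000 nM, with a range from 6000 nM to 70000 nM.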

Compound 4, solubility: 19000 nM
The estimate for compound 4 lay 1.1-fold (0.02 log units) above the measured number; low and high end bracket the measured number.
By their numbers in this assay, from the lowest: compound 3; then compounds 1, 4 and 2 (each within the scatter of the next).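

In this assay, the aromatic carbon para to a large group accepts a change of the ring itself, not only of the substituent on the piperazine nitrogen: the step is a 3.8-fold higher number from compound 3 to compound 4 (0.58 log units; beyond the scatter), and this places compound 4 with compound 1 and compound 2, each within the scatter of the next, leaving compound 3 alone at the low end. The change that does this is a broad one, since the six-membered ring with 2 hetero atoms and the five-membered ring give way to a single six-membered ring with 1 hetero atom, carrying an open diethylamino chain, with the count of hydrogen-bond acceptors going from 3 to 2. No information on the cause of this step is available.

The compounds shown do not separate the contribution of the ring exchange from that of the loss of the oxolan-3-yl group, as the two change together in this single step. A 4-((oxolan-3-yl)methyl)piperidin-1-yl group, or a 4-((diethylamino)methyl)piperazin-1-yl group, would divide the step, while a dimethylamino or pyrrolidin-1-yl group in place of diethylamino would test the end of the chain.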